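Replacing one aryl group: from compound 1 to compound 4

The source may report more compounds than this note shows. Statements on the series, on what has been measured and on what is new or still open speak of the compounds shown alone.

In a functional assay on MCF7 cells (Homo sapiens) for cytotoxicity, read by MTT assay, with a stated time of 24 h (on this read-out lower numbers stand for stronger inhibition and higher numbers for weaker inhibition), compound 1 `COc1cc(/C=C(\C#N)C(=O)N/N=C(\C)c2c(O)c3ccc(O)cc3oc2=O)ccc1O` gives 13700 nM. Compound 2 `C/C(=N\NC(=O)/C(C#N)=C/c1ccc(Br)cc1)c1c(O)c2ccc(O)cc2oc1=O` gives 9850 nM, and compound 3 `C/C(=N\NC(=O)/C(C#N)=C/c1ccc(N(C)C)cc1)c1c(O)c2ccc(O)cc2oc1=O` gives 3420 nM. Compound 1 therefore sits at the high end of the numbers, level with compound 2 within the scatter. Compound 4 `C/C(=N\NC(=O)/C(C#N)=C/c1ccc([N+](=O)[O-])cc1)c1c(O)c2ccc(O)cc2oc1=O` has not been measured yet, and its change is 4-nitrophenyl in place of 4-hydroxy-3-methoxyphenyl on a double-bonded chain carbon bound to a double-bonded chain carbon. Two measured replacements at this same place serve as guides: a 1.4-fold lower number from compound 1 to compound 2 (0.14 log units; within the scatter) and a 4.0-fold lower number from compound 1 to compound 3 (0.60 log units; beyond the scatter). Neither brings in 4-nitrophenyl, so they guide only loosely. A small step is expected in this assay, probably towards a lower number and within the scatter, estimated as a 1.6-fold lower number from compound 1 to compound 4 (0.21 log units; within the scatter). The expected value for compound 4 is 8500 nM, with an estimated range of 3500 nM to 18000 nM.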

Compound 4, half-maximal inhibitory concentration: 8200 nM
Estimate against measurement, compound 4: 1.0-fold (0.02 log units) above; the range from low to high includes it.
By their numbers in this assay, from the lowest: compound 3; then compounds 4, 2 and 1 (each within the scatter of the next).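

In this assay, 4-nitrophenyl at this place gives a 1.7-fold lower number from compound 1 to compound 4 (0.22 log units; within the scatter) and nitro in place of bromo gives a 1.2-fold lower number from compound 2 to compound 4 (0.08 log units; within the scatter) so compounds 1, 2 and 4 remain level despite their different groups. Compound 3 alone stands apart, since nitro in place of dimethylamino gives a 2.4-fold higher number from compound 3 to compound 4 (0.38 log units; beyond the scatter) on the same core. No available measurement explains this difference. On these data alone, whether another amine, such as diethylamino or morpholine, would also stand apart from compounds 1, 2 and 4 remains open, as does the effect of a carboxylic acid here.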